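The source may hold more compounds than are shown below. What is called first, only, known or untested is meant among the compounds shown, and "the series" means these compounds.

Measured in an ADME assay on microsomes from liver (Mus musculus) for metabolic stability, read by LC-MS, with a stated time of 40 min, tested at 0.5 uM; on this read-out lower numbers stand for slow clearance and higher numbers for fast clearance:
- compound 1 `CC(C)(CO)S(=O)(=O)c1cccc(NC(=O)c2cccnc2N2CCC3(CC2)CC3)c1` gives > 399 mL.min-1.g-1 (a limit)
- compound 2 `CC(C)(O)CNc1ccc(C(=O)Nc2cccc(S(=O)(=O)C3CCCC3)n2)c(N2CCC3(CC2)CC3)c1` gives > 399 mL.min-1.g-1 (a limit)
- compound 3 `O=C(Nc1cccc(S(=O)(=O)C2CCCC2)c1)c1cccnc1N1CCCCC1` gives > 399 mL.min-1.g-1 (a limit)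

Compound 1 stands at the assay limit (> 399 mL.min-1.g-1), which is a limit and not a number. Compound 2 and compound 3 stand at the same place, so all three measured compounds share one limit (the limit of > 399 mL.min-1.g-1 in this assay, at which 3 of the 3 values shown sit). Among the compounds with values here, no number therefore separates them, and no measured step shows how a change in structure moves the read-out in this assay.

The next compound is compound 4 `O=C(Nc1cccc(S(=O)(=O)N2CCCC2)c1)c1cccnc1N1CCC2(CC1)CC2`, which keeps the core of compound 1 and has pyrrolidin-1-yl in place of 1-(hydroxymethyl)-1-methylethyl on a sulfonyl sulfur.

With every measured compound at the limit (the limit of > 399 mL.min-1.g-1 in this assay, at which 3 of the 3 values shown sit), no step beyond the usual scatter is expected, and the estimated step of an at least 1.1-fold lower number from compound 1 to compound 4 (0.05 log units; that floor lies within the scatter) is small and towards slower clearance at most. Compound 4 may well return only a limit again. For compound 4 the expected value is 350 mL.min-1.g-1 (estimated range 150 mL.min-1.g-1 to 400 mL.min-1.g-1).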

Compound 4, intrinsic clearance in microsomes: > 399 mL.min-1.g-1
Compound 4 gave a limit, no number; the forecaster's own chance of this, stated with the estimate: 55%; middle value at least 1.1-fold (0.05 log units) away from the limit.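

In this assay, within the data shown here, compound 4 gives > 399 mL.min-1.g-1, a limit and not a number, so no step from compound 1 to compound 4 can be read. The compounds shown leave open whether this change on the sulfonyl sulfur moves clearance at all.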